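Cutting the Aromatic Amide Down to a Single Methyl

The source may report more compounds than this note shows. Statements on the series, on what has been measured and on what is new or still open speak of the compounds shown alone.

Of the compounds shown here, three built on one shared core have been tested in a functional assay on WI-38 VA13 cells (Homo sapiens) for cytotoxicity; on this read-out lower numbers stand for an effect already at smaller amounts and higher numbers for an effect only at larger amounts of compound. Compound 1 `O=C(Nc1ccc2nc(NC(=O)C3CCCCC3)sc2c1)c1ccccc1Oc1ccccc1` gives 0.1 ug/mL, and compound 3 `O=C(Nc1ccc2nc(NC(=O)C3CCCCC3)sc2c1)c1c(F)cccc1C(F)(F)F` gives 0.032 ug/mL. Compound 2 `COc1ccc(C(=O)Nc2ccc3nc(NC(=O)C4CCCCC4)sc3c2)cc1`, which carries a 4-methoxyphenyl group on the carbonyl carbon of its second amide, gives 4.9 ug/mL. That is the highest number of the three, and its differences from compound 1 and from compound 3 both lie beyond the usual scatter of repeated measurements, so compound 2 is the least potent of the measured set.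

Compound 4 `CC(=O)Nc1ccc2nc(NC(=O)C3CCCCC3)sc2c1` has not yet been measured in this assay. It differs from compound 2 in one place: methyl in place of 4-methoxyphenyl on a carbonyl carbon. The whole aromatic group is removed and only a single carbon remains on that carbonyl. Among the compounds with values here, no measured pair shows directly what such a truncation does here; the measured compounds show only that two other aromatic groups give much lower numbers than the methoxyphenyl group of compound 2.

Since the aromatic group appears to carry much of the activity, its removal is expected to push the number further up, and the expected step is a 3.1-fold higher number from compound 2 to compound 4 (0.49 log units; beyond the scatter), a rise beyond the scatter. Compound 4 is therefore expected to give 15 ug/mL, within a range from 4 ug/mL to 50 ug/mL.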

Compound 4, half-maximal effective concentration: 2.7 ug/mL
Estimate against measurement, compound 4: 5.6-fold (0.74 log units) above, outside the stated range (below it).
By their numbers in this assay, from the lowest: compound 3; then compound 1; then compounds 4 and 2 (each within the scatter of the next).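

In this assay, methyl in place of 4-methoxyphenyl on the carbonyl carbon gives a 1.8-fold lower number from compound 2 to compound 4 (0.26 log units; within the scatter), so the two groups cannot be told apart on this read-out, even though nearly all of the group is gone. Simply having an aromatic ring at this position is therefore not enough to reach the low numbers, since compound 1 at 0.1 ug/mL and compound 3 at 0.032 ug/mL stand apart from this pair only with their own particular aromatic groups, while the 4-methoxyphenyl ring of compound 2 shows no measurable gain over a bare methyl. Nothing shown here explains why methyl and 4-methoxyphenyl read alike.

On these data alone, what remains open is where a plain phenyl ring, with no methoxy group, would fall in this assay: with compound 2 and compound 4, or with compound 1 and compound 3. As far as these compounds go, it is also open whether the low numbers need an aromatic ring at all, or whether a non-aromatic group on this carbonyl, such as a longer butyl chain or a chain ending in an amine, could reach them too.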